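Allyloxy to phenylsulfanyl on the shared core

The source may hold more compounds than are shown below. What is called first, only, known or untested is meant among the compounds shown, and "the series" means these compounds.

Compound 1 `Clc1ccc(Sc2ncnc3c2ncn3C2COc3ccccc3CO2)c(Cl)c1`: 12000 nM
Compound 2 `C=CCOc1ncnc2c1ncn2C1COc2ccccc2CO1`: 5040 nM
Compound 3 `c1ccc(Sc2ncnc3c2ncn3C2COc3ccccc3CO2)cc1`: not yet measured

Among the measured compounds shown here, in a functional assay on MCF7 cells (Homo sapiens) for antiproliferative activity, read by sulforhodamine B assay, with a stated time of 3 days (on this read-out higher numbers stand for weaker inhibition and lower numbers for stronger inhibition), compound 2 gives 5040 nM, the lower of the two numbers so far, and compound 1 is its only neighbour. For the measured compounds named here, the one measured step is a 2.4-fold lower number from compound 1 to compound 2 (0.38 log units; beyond the scatter). It is modest and lies beyond the scatter.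

The next change is phenylsulfanyl in place of allyloxy on an aromatic carbon. The measured step bears on this change, since compound 1 carries (2,4-dichlorophenyl)sulfanyl at the place where compound 3 carries phenylsulfanyl. The new step therefore runs roughly against the measured one. Going by the values given here, no measured compound shows a sulfanyl group on an unsubstituted phenyl ring, so the guide is only partial.

In this assay a modest move to a higher number is expected, near the edge of the scatter, with compound 1 at 12000 nM as the nearest reference. The expected step is a 2.0-fold higher number from compound 2 to compound 3 (0.30 log units; within the scatter). For compound 3 the estimated value is 10000 nM, with an expected range of 4000 nM to 25000 nM.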

Compound 3, half-maximal inhibitory concentration: 7120 nM
Compound 3: middle estimate off by 1.4-fold (0.15 log units), on the high side, and the stated range covers the measured number.
By their numbers in this assay, from the lowest: compounds 2, 3 and 1 (each within the scatter of the next, the first and the last beyond it).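

In this assay, the change at this aromatic carbon gives a 1.4-fold higher number from compound 2 to compound 3 (0.15 log units; within the scatter), and the change on the sulfur gives a 1.7-fold lower number from compound 1 to compound 3 (0.23 log units; within the scatter), so neither allyloxy against phenylsulfanyl nor phenyl against 2,4-dichlorophenyl is resolved at this level of scatter. Compound 3 stands within the scatter of both compound 1 and compound 2, so the one difference beyond the scatter, between compound 1 and compound 2, does not divide into a clear share for the sulfanyl link and a clear share for the two chlorines. No independent measurement on hand accounts for these readings.

It remains open whether any group at this position can move the number well beyond the scatter, since the compounds shown carry only allyloxy, phenylsulfanyl and (2,4-dichlorophenyl)sulfanyl there, and an amine such as morpholine or a longer alkoxy chain would probe different ground. The contribution of the shared core also remains open, as all of the compounds shown retain it unchanged.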